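The compounds below may be only part of what the source reports. "The series", "measured", "known", "first", "only" and "open" are said of these compounds alone.

Working notes on the series.

In an assay on HEK293 cells for positive allosteric modulation of metabotropic glutamate receptor 2 (Rattus norvegicus), read by thallium flux, with a stated time of 2.5 min (a higher number here means a larger maximal response, a lower number a smaller maximal response), compound 3 `COC(=O)c1ccc(OCCCCOc2ccc(C(=O)CC3CCCC3)c(C)c2C)cc1` gives 14.1%, the lowest of the three numbers in hand; the nearest is compound 2 `Cc1c(OCCCCOc2ccccc2C(=O)O)ccc(C(=O)CC2CCCC2)c1C` with 67.1%, and the furthest is compound 1 `Cc1c(OCCCCOc2ccc(C(=O)O)cc2)ccc(C(=O)CC2CCCC2)c1O` with 82.6%. For the measured compounds named here, the one measured step that reaches compound 3, a number 53 percentage points lower from compound 2 to compound 3 (beyond the scatter), carries two changes at once, 4-(methoxycarbonyl)phenyl in place of 2-carboxyphenyl, so the share of the ester in that drop cannot be read off on its own.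

Compound 4 `Cc1c(OCCCCOc2ccc(C(=O)O)cc2)ccc(C(=O)CC2CCCC2)c1C` differs from compound 3 only in the ester: hydrogen in place of methyl on an oxygen next to a carbonyl group. Going by the values given here, no measured step isolates this change. Compound 1 carries the same 4-carboxyphenyl end and gives the highest number shown, though its core differs from compound 4 in a second place, so it serves as a pointer only. Taken together with the fall from compound 2 to compound 3, the free acid is expected to bring the response back up in this assay, a step of a number 53.9 percentage points higher from compound 3 to compound 4 (beyond the scatter) being estimated. For compound 4 the expected value in this assay is 68%, with a range of 42% to 90%.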

Compound 4, largest response reached (reported as percent of maximum), in percent of the reference or control that the assay uses: 16.2%
Beside the measured number, compound 4's estimate is 51.8 percentage points above it; the whole stated range lies above it.
By their numbers in this assay, from the lowest: compounds 3 and 4 (each within the scatter of the next); then compound 2; then compound 1.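

In this assay, a number 2.1 percentage points higher from compound 3 to compound 4 (within the scatter) shows that, on the core shared by these two compounds, the methoxycarbonyl and carboxy forms of the 4-substituted phenyl end cannot be told apart. A free carboxy group on its own is therefore not enough for a large maximal response, as a number 50.9 percentage points lower from compound 2 to compound 4 (beyond the scatter) shows: with the same core, 2-carboxyphenyl and 4-carboxyphenyl differ well beyond the scatter. The a number 66.4 percentage points lower from compound 1 to compound 4 (beyond the scatter) adds that the 4-carboxyphenyl end reaches a high number here only with hydroxy on the aromatic carbon, not with methyl.

Still open, going by these compounds, is whether methoxy or fluorine on that aromatic carbon would support the response with the 4-carboxyphenyl end, and how the 2-carboxyphenyl end behaves with hydroxy there. No supporting evidence accounts for the size of these steps.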